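This account rests on a few compounds, and the source may have more. Where it says the series, first, only, none or still open, it means among the compounds named here.

Measured compounds:
Compound 1 `C=C1C(=O)[C@]23C[C@@]1(O)CC[C@H]2c1ccc(O)c(C)c1[C@@H]3Cn1cc(-c2ccc(F)cc2)nn1` gives 940 nM in a functional assay on A549 cells (Homo sapiens) for cytotoxicity, read by MTT assay, with a stated time of 4 days; on this read-out higher numbers stand for weaker inhibition and lower numbers for stronger inhibition.
Compound 3 `C=C1C(=O)[C@]23C[C@@]1(O)CC[C@H]2c1ccc(OS(=O)(=O)c2ccc(C)cc2)c(C)c1[C@@H]3Cn1cc(-c2ccc(F)cc2)nn1` gives 1950 nM in this assay.
Compound 2 `Cc1c(O)ccc2c1[C@H](Cn1cc(-c3ccc(C(F)(F)F)cc3)nn1)[C@@]13CC(=O)[C@@](C)(CC[C@@H]21)C3` reaches only a limit in this assay, > 20000 nM, which is not a number.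

Among the two numbers shown, compound 1 stands lowest, and its nearest neighbour is compound 3, which sits a 2.1-fold higher number from compound 1 to compound 3 (0.32 log units; beyond the scatter). For the measured compounds named here, compound 2 rests at the limit of > 20000 nM in this assay, at which 1 of the 3 values shown sits, and therefore offers no step that can be measured.

The compound still to be tested is compound 4 `C=C1C(=O)[C@]23C[C@@]1(O)CC[C@H]2c1ccc(O)c(C)c1[C@@H]3Cn1cc(-c2ccc(Br)cc2)nn1`. It differs from compound 1 by bromo in place of fluoro on an aromatic carbon. Going by the values given here, no measured step touches this part of the shared core: the only step known, from compound 1 to compound 3, concerns the phenol oxygen and is modest, while compound 2 changes several places at once and gives only a limit. The exchange of one halogen for another at the far end of the aryl group, with no change in ring count, donors, acceptors or charge, gives no reason to expect more than scatter in this assay.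

Compound 4 is therefore expected to land at 900 nM, between 400 nM and 2500 nM, a step of a 1.0-fold lower number from compound 1 to compound 4 (0.02 log units; within the scatter) that is estimated to stay within the scatter.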

Compound 4, half-maximal inhibitory concentration: 1140 nM
The estimate for compound 4 lay 1.3-fold (0.10 log units) below the measured number; the measured number falls inside the stated range.
By their numbers in this assay, from the lowest: compounds 1, 4 and 3 (each within the scatter of the next, the first and the last beyond it). At a limit, above all of these: compound 2.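

In this assay, exchanging 4-fluorophenyl for 4-bromophenyl gives a 1.2-fold higher number from compound 1 to compound 4 (0.08 log units; within the scatter), so the swap of one halogen for the other leaves the cytotoxicity reading unchanged within normal assay variation. For the compounds shown here, this is the first measured step at this place, on an aromatic carbon para to a large group; the only earlier step in the shared core was at an oxygen on an aromatic ring, a 2.1-fold higher number from compound 1 to compound 3 (0.32 log units; beyond the scatter), and it could say nothing about the halogen. The result therefore shows that, in this assay, this position accepts either fluoro or bromo without a reading change beyond the scatter, although nothing shown here explains why the two behave alike.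

Fluoro and bromo are the only groups compared at this place while the rest of compound 1 stays fixed, so it remains open whether plain hydrogen, an amine, a carboxylic acid or a longer chain such as butyl would keep the reading or shift it. On these data alone, it also remains open whether the match between compound 1 and compound 4 holds on any cell type other than the one used here.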